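Methoxy for Methyl on a Benzyl-Substituted Nucleoside

The source may report more compounds than this note shows. Statements on the series, on what has been measured and on what is new or still open speak of the compounds shown alone.

Measured so far:
compound 1 `OC[C@H]1O[C@@H](n2cnc3c(NCc4cccc(Br)c4)ncnc32)[C@H](O)[C@@H]1O`, > 166000 nM
compound 2 `Cc1cccc(CNc2ncnc3c2ncn3[C@@H]2O[C@H](CO)[C@@H](O)[C@H]2O)c1`, > 166000 nM

Both measured compounds stop at a limit rather than giving a number. In a functional assay on G-361 cells (Homo sapiens) for antiproliferative activity, with a stated time of 72 h (a lower number here means a stronger inhibitor, a higher number a weaker inhibitor), compound 1 gives > 166000 nM, which is a limit of the assay. Compound 2 gives > 166000 nM, which is again a limit of the assay. The step that the two limits leave unreadable from compound 1 to compound 2 cannot be read because of the limit of > 166000 nM in this assay, at which 2 of the 2 values shown sit. Compound 2 therefore stands only at a limit, with no numerical value to place it against anything else.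

Compound 3 `COc1ccccc1CNc1ncnc2c1ncn2[C@@H]1O[C@H](CO)[C@@H](O)[C@H]1O` differs from compound 2 by 2-methoxyphenyl in place of 3-methylphenyl on a saturated chain carbon bound to a nitrogen on an aromatic ring. For the measured compounds named here, the only measured step is unreadable; nothing measured fixes the size or direction of this change. With both measured compounds at the same limit, the plain expectation is that compound 3 stays in the same place, and the step that the limit leaves unreadable from compound 2 to compound 3 is expected to be no more than scatter. Compound 3 is therefore estimated at 250000 nM, with a range from 80000 nM to 800000 nM, and most likely reported only as a limit.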

Compound 3, half-maximal inhibitory concentration: > 166000 nM
Compound 3: no number, only a limit; the forecaster's own chance of this, stated with the estimate: 85%; the middle value lies beyond the limit too.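

For the compounds shown here, compound 3 also stops at a limit, so the steps to it from compound 1 and from compound 2 cannot be read, and no new step comes from this result: the limit of > 166000 nM in this assay, at which 3 of the 3 values shown sit. Compound 1, compound 2 and compound 3 leave open whether 3-bromophenyl, 3-methylphenyl and 2-methoxyphenyl differ at all in this assay, as none of the three has a number there.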